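The source may report more compounds than this note shows. Statements on the series, on what has been measured and on what is new or still open speak of the compounds shown alone.

Compound 1 `Cc1cccc(C#Cc2cc(Cl)cc(C#N)c2)n1`: 1.22 nM
Compound 2 `Cc1cccc(C#Cc2cc(F)cc(C#N)c2)n1`: 1.22 nM

In a functional assay on HEK293 cells for antagonist activity at metabotropic glutamate receptor 5 (Rattus norvegicus), read by calcium flux (on this read-out lower numbers stand for stronger inhibition and higher numbers for weaker inhibition), compound 2 stands level with compound 1; the step of no change at the digits printed from compound 1 to compound 2 (within the scatter) lies within the scatter. Compound 3 `Cc1cccc(C#Cc2cc(I)cc(C#N)c2)n1` differs from compound 2 by iodo in place of fluoro on an aromatic carbon. Within the data shown here, the only measured step that bears on this is the earlier halogen swap, which gave no change at the digits printed from compound 1 to compound 2 (within the scatter) and so showed no movement beyond the scatter. A further halogen swap in this assay is therefore expected to give no step beyond the scatter, in no clear direction. Compound 3 is expected at 1.5 nM, between 0.5 nM and 4.5 nM, a step of a 1.2-fold higher number from compound 2 to compound 3 (0.09 log units; within the scatter) that is expected to stay within the scatter.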

Compound 3, half-maximal inhibitory concentration: 0.71 nM
The estimate for compound 3 lay 2.1-fold (0.32 log units) above the measured number; the measured number falls inside the stated range.
By their numbers in this assay, from the lowest: compounds 3, 1 and 2 (each within the scatter of the next).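

In this assay, iodo, fluoro and chloro, on this aromatic carbon meta to a cyano group, all lie within the scatter of one another (a 1.7-fold lower number from compound 2 to compound 3 (0.24 log units; within the scatter); a 1.7-fold lower number from compound 1 to compound 3 (0.24 log units; within the scatter)). The flat result of the first halogen swap therefore extends to iodo, and no step among these three halogens stands out from the scatter. No evidence is at hand that accounts for this. Going by these compounds, whether an amine, a methoxy group or a carboxylic acid at the same place would stay within that scatter remains open.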